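Aspirin esters: from a phenyl ester to a glycolamide ester

The source may hold more compounds than are shown below. What is called first, only, known or untested is meant among the compounds shown, and "the series" means these compounds.

Three compounds of the series have a measured value in a physicochemical assay for lipophilicity; a higher number here means a more lipophilic compound, a lower number a more polar compound. Compound 1 `CCOC(=O)CN(C)C(=O)COC(=O)c1ccccc1OC(C)=O` gives 1.67; compound 2 `CC(=O)Oc1ccccc1C(=O)OCC(=O)N(C)CCO` gives 0.06; compound 3 `CC(=O)Oc1ccccc1C(=O)Oc1ccccc1` gives 2.88, the highest of the three numbers, with compound 1 as its nearest neighbour and compound 2 the furthest away. Among the compounds with values here, the only step between compounds that differ in one place is a number 1.61 log units lower from compound 1 to compound 2 (beyond the scatter), hydroxymethyl in place of ethoxycarbonyl on a saturated chain carbon bound to an amide-type nitrogen; it does not touch the ester oxygen.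

Compound 4 `CCNC(=O)COC(=O)c1ccccc1OC(C)=O` is not yet measured. It differs from compound 3 as follows: (ethylcarbamoyl)methyl in place of phenyl on an oxygen next to a carbonyl group. Within the data shown here, no measured step covers this change. What can be drawn on is that compound 1, which also carries a carbamoylmethyl-type group on the ester oxygen, sits well under compound 3 in this assay, and that compound 4 carries one donor on its amide where compound 1 carries none. A step downward beyond the scatter is therefore expected, roughly a number 1.48 log units lower from compound 3 to compound 4 (beyond the scatter). For compound 4 the estimate is 1.4, within 0.9 to 1.9.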

Compound 4, partition coefficient: 0.9
The estimate for compound 4 lay 0.50 log units above the measured number; the range from low to high includes it.
By their numbers in this assay, from the lowest: compound 2; then compound 4; then compound 1; then compound 3.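

Within the data shown here, on an oxygen next to a carbonyl group, (ethylcarbamoyl)methyl in place of phenyl gives a number 1.98 log units lower from compound 3 to compound 4 (beyond the scatter) in this assay, the first measured step at this place that starts from the phenyl ester. With that ester side otherwise shared, the group on the carbonyl carbon moves the number both ways: ethylamino in place of ((ethoxycarbonyl)methyl)(methyl)amino gives a number 0.77 log units lower from compound 1 to compound 4 (beyond the scatter) and ethylamino in place of (2-hydroxyethyl)(methyl)amino gives a number 0.84 log units higher from compound 2 to compound 4 (beyond the scatter) in this series. No measurement shown accounts for any of these steps.

Where dimethylamino on the carbonyl carbon would stand remains open, and with it how much of these steps belongs to the amide hydrogen rather than to the rest of the group. Also open, as far as these compounds go, is how a carboxylic acid in place of the ethoxycarbonyl of compound 1 would read.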